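The source may hold more compounds than are shown below. What is called first, only, known or untested is meant among the compounds shown, and "the series" means these compounds.

Working notes on the series. Going by the values given here, compound 1 `Cc1cc(O)c(C(=O)/C=C/c2ccc(F)cc2)c(-c2ccc(Br)cc2)c1C(=O)/C=C/c1ccc(F)cc1` gives 20000 nM in an ADME assay on HEK293 cells (Homo sapiens) for cytotoxicity, read by MTT assay, with a stated time of 24 h (a higher number here means a weaker inhibitor, a lower number a stronger inhibitor), and is one of only two members with a number in hand. Compound 2 `Cc1cc(O)c(C(=O)/C=C/c2ccccc2)c(-c2ccc(Br)cc2)c1C(=O)/C=C/c1ccccc1` gives 30000 nM in this assay, and the gap to compound 1 lies within the scatter, so the two cannot be told apart. Compound 3 `COc1ccc(/C=C/C(=O)c2c(C)cc(O)c(C(=O)/C=C/c3ccc(OC)c(OC)c3)c2-c2ccccc2)cc1OC` is recorded in this assay as "not active" (no number reported), without a number. Compound 4 `Cc1cc(O)c(C(=O)/C=C/c2ccc(F)cc2)c(-c2ccccc2)c1C(=O)/C=C/c1ccc(F)cc1` is the next member to be tested. From compound 1 it differs by hydrogen in place of bromo on an aromatic carbon. Among the compounds with values here, no measured pair in this set shows the size of such a change, so nothing here fixes its direction. A step within the scatter is expected, a 1.5-fold higher number from compound 1 to compound 4 (0.18 log units; within the scatter). The estimate for compound 4 is 30000 nM, in a range from 12000 nM to 80000 nM.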

Compound 4, half-maximal inhibitory concentration: "not active" (no number reported)
The entry for compound 4 holds no number; no gap can be computed for the estimate.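

Going by these compounds alone, with compound 4 at "not active" (no number reported), no step from compound 1 can be read, and no supporting evidence bears on this result. As far as these compounds go, what the change from 4-bromophenyl to phenyl does in this assay stays open.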